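Cinnamanilide series: propargyloxy for methoxy on the styryl ring

This account rests on a few compounds, and the source may have more. Where it says the series, first, only, none or still open, it means among the compounds named here.

Measured so far:
compound 1 `C#CCOc1cccc(/C=C/C(=O)Nc2cc(C(=O)c3cc(OC)c(OC)c(OC)c3)ccc2OC)c1` — 12200 nM
compound 2 `COc1ccc(/C=C/C(=O)Nc2cc(C(=O)c3cc(OC)c(OC)c(OC)c3)cc(OC)c2OC)cc1` — 9400 nM

In a functional assay on B16 cells (Mus musculus) for cytotoxicity, read by MTT assay, with a stated time of 72 h (a higher number here means a weaker inhibitor, a lower number a stronger inhibitor), compound 1 gives 12200 nM and compound 2 gives 9400 nM. Compound 2 stands at the lower of the two numbers, but compound 1 lies within the usual scatter of it, so the two are not told apart by this assay. Going by the values given here, no pair of measured compounds differs in a single place, so no step for a single change is available.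

Compound 3 `C#CCOc1cccc(/C=C/C(=O)Nc2cc(C(=O)c3cc(OC)c(OC)c(OC)c3)cc(OC)c2OC)c1` carries 3-(propargyloxy)phenyl in place of 4-methoxyphenyl on a double-bonded chain carbon bound to a double-bonded chain carbon. The same propargyloxy group is present in compound 1, whose number in this assay is within the scatter of compound 2, and nothing here points to a change beyond the scatter. The step from compound 2 to compound 3 is therefore expected to be small, about a 1.2-fold higher number from compound 2 to compound 3 (0.07 log units; within the scatter). For compound 3 the expected value in this assay is 11000 nM, with a range from 4500 nM to 28000 nM.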

Compound 3, half-maximal inhibitory concentration: 5100 nM
The estimate for compound 3 lay 2.2-fold (0.33 log units) above the measured number, and the stated range covers the measured number.
By their numbers in this assay, from the lowest: compounds 3, 2 and 1 (each within the scatter of the next, the first and the last beyond it).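

In this assay, 3-(propargyloxy)phenyl in place of 4-methoxyphenyl on a double-bonded chain carbon bound to a double-bonded chain carbon gives a 1.8-fold lower number from compound 2 to compound 3 (0.27 log units; within the scatter) and so is not told apart from no change at this place. Going by these compounds alone, with 3-(propargyloxy)phenyl held fixed, methoxy in place of hydrogen on an aromatic carbon gives a 2.4-fold lower number from compound 1 to compound 3 (0.38 log units; beyond the scatter) and is the only single change here that reaches beyond the scatter, though modestly. Nothing available accounts for either step.

In the pair of compound 2 and compound 3, the group and its place on the ring change together, and the effect of each remains unresolved. Also open, from the compounds shown here alone, is how a 3-aminophenyl or a 3-carboxyphenyl group at this place would read in this assay against compound 3.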